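Chain extension on the aryl group: from ethyl to butyl

A few compounds are considered here, and "the series" means these few. Any claim that something is new, unique, unknown or untested is made for them only; others in the source may bear on it.

Measured compounds:
compound 1 `CCCc1ccc(N2C(=O)NC3(CSC4=C3C(=O)c3ncccc3C4=O)C2=O)cc1` — 300 nM
compound 2 `CCN(CC)c1ccc(N2C(=O)NC3(CSC4=C3C(=O)c3ncccc3C4=O)C2=O)cc1` — 960 nM
compound 3 `CCc1ccc(N2C(=O)NC3(CSC4=C3C(=O)c3ncccc3C4=O)C2=O)cc1` — 450 nM

All three share one core and differ only in the substituent on the aromatic carbon. In a functional assay on SF-268 cells (Homo sapiens) for antiproliferative activity, read by MTT assay, with a stated time of 96 h (on this read-out higher numbers stand for weaker inhibition and lower numbers for stronger inhibition), compound 3 gives 450 nM, the second highest of the three numbers. Its nearest neighbour is compound 1, with a step of a 1.5-fold higher number from compound 1 to compound 3 (0.18 log units; within the scatter). Compound 2 lies furthest away, with a step of a 2.1-fold lower number from compound 2 to compound 3 (0.33 log units; beyond the scatter); the other step in the set is a 3.2-fold higher number from compound 1 to compound 2 (0.51 log units; beyond the scatter).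

Compound 4 `CCCCc1ccc(N2C(=O)NC3(CSC4=C3C(=O)c3ncccc3C4=O)C2=O)cc1` has not been measured. Its change from compound 3 is ethyl in place of hydrogen on a saturated chain carbon, two bonds along the chain from an aromatic carbon. Within the data shown here, the step that bears on it most directly is the one from compound 1 to compound 3, which also alters the length of the saturated chain and stayed within the scatter. The two steps involving compound 2 exchange the chain for diethylamino and so speak less directly to a further extension of the chain. On this basis a small step is expected, if anything toward a lower number, of about a 1.4-fold lower number from compound 3 to compound 4 (0.15 log units; within the scatter). Compound 4 is therefore estimated at 320 nM in this assay, in the range 130 nM to 800 nM.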

Compound 4, half-maximal inhibitory concentration: 400 nM
Compound 4: the middle estimate sits 1.3-fold (0.10 log units) below what was measured; the range from low to high includes it.
By their numbers in this assay, from the lowest: compounds 1, 4 and 3 (each within the scatter of the next); then compound 2.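

In this assay, among these compounds, ethyl in place of hydrogen on a saturated chain carbon, two bonds along the chain from an aromatic carbon, gives a 1.1-fold lower number from compound 3 to compound 4 (0.05 log units; within the scatter), and the butyl chain also stays close to the propyl chain, with a 1.3-fold higher number from compound 1 to compound 4 (0.12 log units; within the scatter), so the ethyl, propyl and butyl groups now form a set of three that this assay cannot separate, where the earlier compounds held only a single such pair. The diethylamino group remains apart from this set, since butyl in its place gives a 2.4-fold lower number from compound 2 to compound 4 (0.38 log units; beyond the scatter), a step beyond the scatter like those already seen for ethyl and propyl, and so compound 2 is the only one of the four that stands clear of the others. No measurement is available that would explain the flat response to chain length or the separate place of the diethylamino compound.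

The compounds shown leave open whether the same flat response holds for a longer chain such as hexyl or octyl, or for a branched group such as tert-butyl. They also leave open what a chain ending in a hydroxyl group, an amine or a carboxylic acid would do, and whether a smaller dimethylamino group would sit with the chains or with compound 2.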